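A Larger Group on the Same Core

This account rests on a few compounds, and the source may have more. Where it says the series, first, only, none or still open, it means among the compounds named here.

In a functional assay on K562 cells (Homo sapiens) for inhibition, read by trypan blue exclusion, with a stated time of 72 h (on this read-out lower numbers stand for stronger inhibition and higher numbers for weaker inhibition), compound 1 `Cn1c(=O)c(S(=O)(=O)c2ccc(F)cc2F)cc2cnc(Nc3ccc4[nH]ncc4c3)nc21` gives 50000 nM, and compound 2 `Cn1c(=O)c(S(=O)(=O)c2ccc(F)cc2F)cc2cnc(Nc3ccccn3)nc21` gives 35000 nM. Going by the values given here, these are the only two numbers so far, and they lie within the scatter of each other, so compound 2 stands level with compound 1 rather than ahead of it. Compound 3 `Cn1c(=O)c(S(=O)(=O)c2ccc(F)cc2F)cc2cnc(Nc3cnc4[nH]ccc4c3)nc21` keeps the shared core and changes one group on a nitrogen on an aromatic ring: a group of 9 heavy atoms (7 carbon, 2 nitrogen; one five-membered aromatic ring with 1 hetero atom, one six-membered aromatic ring with 1 hetero atom) in place of a group of 6 heavy atoms (5 carbon, 1 nitrogen; one six-membered aromatic ring with 1 hetero atom), on a nitrogen on an aromatic ring. Among the compounds with values here, the one measured step that bears on this, with pyridin-2-yl in place of 1H-indazol-5-yl on that same nitrogen, is a 1.4-fold lower number from compound 1 to compound 2 (0.15 log units; within the scatter). Within the data shown here, with that single small step as the only guide, no change beyond the scatter is expected in this assay, although one step is thin evidence and no measured compound carries the new group. The expected size, with no firm direction, is a 1.1-fold higher number from compound 2 to compound 3 (0.06 log units; within the scatter). For compound 3 the estimate is 40000 nM, with an expected range from 12000 nM to 90000 nM.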

Compound 3, half-maximal inhibitory concentration: 750 nM
Compound 3: middle estimate off by 53-fold (1.73 log units), on the high side; the measured number lies below the stated range.
By their numbers in this assay, from the lowest: compound 3; then compounds 2 and 1 (each within the scatter of the next).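

Going by these compounds alone, the group on this nitrogen can shift the result strongly in this assay, where the change gives a 47-fold lower number from compound 2 to compound 3 (1.67 log units; beyond the scatter) and is the first step here beyond the scatter. Size alone does not account for this, as the group of compound 1 has the same count of heavy atoms, carbon and nitrogen as the group of compound 3, and still a 67-fold lower number from compound 1 to compound 3 (1.82 log units; beyond the scatter) follows from moving from two hetero atoms in the five-membered ring to one hetero atom in each ring. So the placing of the nitrogens within these two-ring groups matters at this position, though nothing measured here gives a reason for the gain.

On these data alone, it remains open whether the hydrogen on the nitrogen of the five-membered ring is needed, which a methyl group in its place would test, and whether the nitrogen of the six-membered ring counts for as much, which a plain indol-5-yl group would test. As far as these compounds go, it is also open whether the gain would hold if the difluorophenyl group on the sulfonyl gave way to a simple phenyl group.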